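From 3-Hydroxybenzyl to 3,4-Dinitrophenyl on the Same Core

The compounds below may be only part of what the source reports. "The series", "measured", "known", "first", "only" and "open" are said of these compounds alone.

Going by the values given here, in a functional assay on RS4-11 cells (Homo sapiens) for inhibition, read by CCK-8 assay, with a stated time of 48 h (on this read-out lower numbers stand for stronger inhibition and higher numbers for weaker inhibition), compound 1 `O=C(NCCNS(=O)(=O)c1ccc(-c2ccccc2OCc2cccc(O)c2)s1)Nc1cc(C(F)(F)F)cc(C(F)(F)F)c1` gives 3000 nM, the lower of the two numbers measured so far. Compound 2 `O=S(=O)(NCCNC(=S)Nc1cc(C(F)(F)F)cc(C(F)(F)F)c1)c1ccc(-c2ccccc2Oc2ccc(O)c(O)c2)s1` gives 10300 nM, a gap beyond the usual scatter. Compound 3 `O=C(NCCNS(=O)(=O)c1ccc(-c2ccccc2Oc2ccc([N+](=O)[O-])c([N+](=O)[O-])c2)s1)Nc1cc(C(F)(F)F)cc(C(F)(F)F)c1` keeps the core of compound 1 and alters one group: 3,4-dinitrophenyl in place of 3-hydroxybenzyl on an oxygen on an aromatic ring. Here, 3,4-dinitrophenyl stands in place of 3-hydroxybenzyl on an oxygen on an aromatic ring. Among the compounds with values here, no pair of measured compounds differs in just one place, so the data offer no direct guide to this swap. With compound 1 the lower of the two and compound 2 at 10300 nM the only other reference, a higher number seems likelier than a lower one. In this assay, the expected change is a modest move toward weaker inhibition, a 2.0-fold higher number from compound 1 to compound 3 (0.30 log units; within the scatter). The estimate for compound 3 is 6000 nM, with an expected range of 1500 nM to 24000 nM.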

Compound 3, half-maximal inhibitory concentration: 2400 nM
Compound 3: the middle estimate sits 2.5-fold (0.40 log units) above what was measured; the range from low to high includes it.
By their numbers in this assay, from the lowest: compounds 3 and 1 (each within the scatter of the next); then compound 2.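

In this assay the swap of 3-hydroxybenzyl for 3,4-dinitrophenyl on an oxygen on an aromatic ring gives a 1.3-fold lower number from compound 1 to compound 3 (0.10 log units; within the scatter) and so cannot be told apart from no change on this read-out. This place on the core of compound 1 therefore accepts two quite different groups: one with 8 heavy atoms, 1 hydrogen-bond donor and 1 hydrogen-bond acceptor, and one with 12 heavy atoms, 0 hydrogen-bond donors and 4 hydrogen-bond acceptors. No measurement shown here explains why the two groups perform alike.

The compounds shown leave open what a plain phenyl, a single nitro group, an amine or a carboxylic acid would do at this place. On these data alone, how a longer chain on the same oxygen would fare also remains open.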